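A few compounds are considered here, and "the series" means these few. Any claim that something is new, unique, unknown or untested is made for them only; others in the source may bear on it.

Within the data shown here, compound 2 (`CC(C)(C)C1=NN(c2cccc(F)c2)C(c2ccc(O)cc2)C1`) gives 2200 nM in an assay on isolated protein for inhibition of protein kinase C zeta type (Homo sapiens), with a stated time of 4 min (on this read-out higher numbers stand for weaker inhibition and lower numbers for stronger inhibition), the lowest of the two numbers so far, while compound 1 (`CC(C)(C)C1=NN(c2cccc(Cl)c2)C(c2ccc(O)cc2)C1`) gives 5200 nM. Among the measured compounds shown here, the single measured step is a 2.4-fold lower number from compound 1 to compound 2 (0.37 log units; beyond the scatter). Compound 3 (`CC(C)(C)C1=NN(c2cccc(C(F)(F)F)c2)C(c2ccc(O)cc2)C1`) differs from compound 2 by trifluoromethyl in place of fluoro on an aromatic carbon. For the measured compounds named here, no measured step covers this change directly, and the one step in hand does not point to a gain here, so for compound 3 the expected step in this assay is a 2.7-fold higher number from compound 2 to compound 3 (0.44 log units; beyond the scatter), toward a higher number. Compound 3 is estimated at 6000 nM, with a range from 2000 nM to 18000 nM.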

Compound 3, half-maximal inhibitory concentration: 2700 nM
Beside the measured number, compound 3's estimate is 2.2-fold (0.35 log units) above it, within the range that was stated.
By their numbers in this assay, from the lowest: compounds 2, 3 and 1 (each within the scatter of the next, the first and the last beyond it).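

In this assay, trifluoromethyl in place of fluoro on this aromatic carbon gives a 1.2-fold higher number from compound 2 to compound 3 (0.09 log units; within the scatter) even though 4 heavy atoms replace 1, so the larger group is accommodated here. Trifluoromethyl in place of chloro gives a 1.9-fold lower number from compound 1 to compound 3 (0.28 log units; within the scatter) and thus compound 3 cannot be ordered against compound 1 or compound 2, although those two stand apart. No evidence on record bears on why these three substituents read as they do. Still open, on these data alone, is whether an amine, a carboxylic acid or a methoxy group at this carbon would shift the number beyond the scatter.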